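Swapping a methoxyphenyl for a fluorophenyl: what happens to clearance

The source may report more compounds than this note shows. Statements on the series, on what has been measured and on what is new or still open speak of the compounds shown alone.

Measured compounds:
Compound 1: `COc1cccc(S(=O)(=O)c2cnc3cc(F)ccc3c2-c2cccc(F)c2)c1` — 3.36 mL/min
Compound 2: `COc1ccc(-c2c(S(=O)(=O)c3cccc(C#N)c3)cnc3cc(F)ccc23)cc1` — 0.92 mL/min

Of the compounds shown here, two on a shared core have been tested in an ADME assay on microsomes from liver (Homo sapiens) for metabolic stability, tested at 2.5 uM; a higher number here means faster removal of the compound, a lower number slower removal. Compound 1 gives 3.36 mL/min in this assay. Compound 2 gives 0.92 mL/min in this assay, the lowest of the two numbers; the gap to compound 1 lies beyond the usual scatter, so compound 2 is removed more slowly than compound 1.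

The next compound, compound 3 `N#Cc1cccc(S(=O)(=O)c2cnc3cc(F)ccc3c2-c2cccc(F)c2)c1`, has not yet been measured in this assay. It is built from compound 2 by one change: 3-fluorophenyl in place of 4-methoxyphenyl on an aromatic carbon. A group with one hydrogen-bond acceptor leaves, and a smaller group with none enters.

Going by the values given here, no measured pair here shows the effect of this exact change, so any forecast rests only on the two numbers above. A moderate rise in this assay is expected, and the step to compound 3 is estimated as a 1.8-fold higher number from compound 2 to compound 3 (0.27 log units; within the scatter). The expected value for compound 3 in this assay is 1.7 mL/min, within a range from 0.7 mL/min to 4 mL/min.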

Compound 3, intrinsic clearance in a liver preparation (reported as CLH), per the amount of preparation that the assay uses: 0.78 mL/min
For compound 3 the middle estimate is 2.2-fold (0.34 log units) above the measured one; the measured number falls inside the stated range.
By their numbers in this assay, from the lowest: compounds 3 and 2 (each within the scatter of the next); then compound 1.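

At this position, the aromatic carbon opposite the ring nitrogen, swapping 4-methoxyphenyl for 3-fluorophenyl leaves the read-out in this assay unresolved, with a 1.2-fold lower number from compound 2 to compound 3 (0.07 log units; within the scatter); the two groups cannot be told apart here, even though they differ in size and in hydrogen-bond acceptors. With 3-fluorophenyl held in place on the shared core, the new compound also allows a second single-change comparison, cyano in place of methoxy on an aromatic carbon, and that change gives a 4.3-fold lower number from compound 1 to compound 3 (0.63 log units; beyond the scatter), a step that clears the scatter. Nothing available here explains either step.

From the compounds shown here alone, each change has been read only once and against one partner group, so it remains open whether cyano in place of methoxy would give a similar step with 4-methoxyphenyl in place of 3-fluorophenyl. Going by these compounds, it is also open whether the insensitivity to the swap at this position holds for very different groups there, such as an amine or a carboxylic acid, since both groups compared so far are substituted phenyl rings.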